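The compounds below may be only part of what the source reports. "The series", "measured", "known", "first", "only" and "open" are said of these compounds alone.

Within the data shown here, in an ADME assay on L1210 cells (Mus musculus) for cytotoxicity, with a stated time of 48 h (on this read-out lower numbers stand for stronger inhibition and higher numbers for weaker inhibition), only two compounds have numbers so far. Compound 1 `C=C1[C@H](C)CCC[C@]1(C)CC/C(C)=C/CC1=C(O)C(=O)C=C(N[C@@H](C(=O)O)[C@H](C)O)C1=O` gives 4.6 ug/mL and holds the higher of the two numbers, which marks it as the weaker inhibitor of the pair. Among the measured compounds shown here, compound 2 `COC1=CC(=O)C(O)=C(C/C=C(\C)CC[C@@]2(C)CCC=C(C)[C@H]2C)C1=O` gives 2 ug/mL and is its only neighbour on this scale, with a gap that lies beyond the usual scatter of repeated measurements.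

Compound 3 `C=C1[C@H](C)CCC[C@]1(C)CC/C(C)=C/CC1=C(O)C(=O)C=C(OC)C1=O` still awaits measurement. The change from compound 1 is methoxy in place of (1-carboxy-2-hydroxypropyl)amino on a double-bonded ring carbon and, in words, methoxy stands in place of (1-carboxy-2-hydroxypropyl)amino on a double-bonded ring carbon. For the measured compounds named here, no measured pair shows this exchange on its own, so any forecast remains uncertain. Going by the values given here, the only guide is compound 2, which also carries a methoxy group and gives 2 ug/mL in this assay as its result. A lower number than that of compound 1 is therefore expected, though the shift may be modest and not far outside the scatter. The estimated move is a 2.0-fold lower number from compound 1 to compound 3 (0.30 log units; within the scatter) on this scale. For compound 3 the expected value is 2.3 ug/mL with an estimated range of 1 ug/mL to 5.5 ug/mL around it.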

Compound 3, half-maximal inhibitory concentration: 2.4 ug/mL
Estimate against measurement, compound 3: 1.0-fold (0.02 log units) below; the range from low to high includes it.
By their numbers in this assay, from the lowest: compounds 2, 3 and 1 (each within the scatter of the next, the first and the last beyond it).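

On this double-bonded ring carbon, methoxy in place of (1-carboxy-2-hydroxypropyl)amino gives a 1.9-fold lower number from compound 1 to compound 3 (0.28 log units; within the scatter) in this assay, so this exchange does not separate the two compounds on this scale. The result therefore shows that, for this pair, the position accepts both a group of 8 heavy atoms with 3 hydrogen-bond donors and 2 defined stereocentres and a group of 2 heavy atoms with 0 hydrogen-bond donors, without a difference beyond the usual scatter. No measurement given here offers an explanation for this outcome.

The compounds shown leave open whether other groups on this ring carbon, such as a plain amino group, a longer butoxy chain or a single chlorine atom, would also stay within the scatter of compound 1. They also leave open whether the carboxylic acid and the hydroxy group within the (1-carboxy-2-hydroxypropyl)amino group matter individually, as that group is exchanged here only as a whole.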